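The source may report more compounds than this note shows. Statements on the series, on what has been measured and on what is new or still open speak of the compounds shown alone.

Compound 1 `COc1ccc(N(CC(=O)NCCC[Te]c2ccccc2)C(=O)CNC(=O)OC(C)(C)C)cc1`: in a functional assay on A-431 cells (Homo sapiens) for cytotoxicity, read by MTT assay, with a stated time of 24 h (on this read-out higher numbers stand for weaker inhibition and lower numbers for stronger inhibition), compound 1 gives 5000 nM. Compound 2 `O=C(COC(=O)/C=C/c1ccccc1)NCCC[Te]c1ccccc1`: compound 2 gives 6000 nM. Compound 3 `COc1ccc(N(CC(=O)NCCCSc2ccccc2)C(=O)CNC(=O)OC(C)(C)C)cc1`: compound 3 reaches only a limit of the assay, >= 100000 nM.

Compound 1 holds the lowest of the two proper numbers, with compound 2 within the scatter of it. For the measured compounds named here, the one measured step, an at least 20-fold higher number from compound 1 to compound 3 (1.30 log units; beyond the scatter), rests on the limit of >= 100000 nM in this assay, at which 1 of the 3 values shown sits, and swaps the tellurium-bearing group for a sulfur-bearing one. Compound 4 `COc1ccc(N(CC(=O)NCCC[Te]c2ccccc2)C(=O)c2ccccc2)cc1` keeps that tellurium group and differs from compound 1 only by phenyl in place of ((tert-butoxycarbonyl)amino)methyl on a carbonyl carbon. Going by the values given here, no measured step touches this part of the molecule, so the expected step in this assay is no change at the digits printed from compound 1 to compound 4 (within the scatter), none beyond the scatter. For compound 4 the estimate is 5000 nM, expected between 1500 nM and 20000 nM.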

Compound 4, half-maximal inhibitory concentration: 5000 nM
For compound 4 middle estimate and measured number coincide at the digits printed; measured number inside the range.
By their numbers in this assay, from the lowest: compounds 1, 4 and 2 (each within the scatter of the next). At a limit, above all of these: compound 3.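

Putting phenyl in place of ((tert-butoxycarbonyl)amino)methyl on this carbonyl carbon gives no change at the digits printed from compound 1 to compound 4 (within the scatter) in this assay. The earlier compounds shown here did not touch this part of the molecule; this step shows that the open chain and its hydrogen-bond donor are not needed to keep this number, and that an aromatic ring can stand here instead. Nothing given here explains why the number holds.

From the compounds shown here alone, whether an amine, a carboxylic acid or a longer chain on this carbonyl carbon would also keep the number remains open. So does whether sulfur in place of tellurium would act on compound 4 as it did on compound 1.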